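The compounds below may be only part of what the source reports. "The series", "measured", "known", "first", "only" and "open" are said of these compounds alone.

Values in a functional assay on the whole organism with Rattus norvegicus as the target (a higher number here means that more compound is needed for the effect, a lower number that less compound is needed), so far:
compound 1 `CCOC(=O)C(=O)Nc1cccc(OC)c1C#N` gives 5.3 mg/kg
compound 2 `CCOC(=O)C(=O)Nc1cccc(N2CCCCC2)c1C#N` gives 2.2 mg/kg

Compound 2 holds the lower of the two numbers. Compound 3 `CCOC(=O)C(=O)Nc1cccc(C)c1C#N` differs from it by methyl in place of piperidin-1-yl on an aromatic carbon with methyl in place of piperidin-1-yl on an aromatic carbon. Only a 2.4-fold lower number from compound 1 to compound 2 (0.38 log units; beyond the scatter) bears on this, for piperidin-1-yl in place of methoxy at the same place, and it suggests a modest move to a higher number once piperidin-1-yl leaves. The expected change is a 2.3-fold higher number from compound 2 to compound 3 (0.36 log units; beyond the scatter) in this estimate. The estimate for compound 3 is 5 mg/kg (range 2.2 mg/kg to 12 mg/kg) .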

Compound 3, dose for half-maximal effect: 5.3 mg/kg
Compound 3: middle estimate off by 1.1-fold (0.03 log units), on the low side, and the stated range covers the measured number.
By their numbers in this assay, from the lowest: compound 2; then compounds 1 and 3 (each within the scatter of the next).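

In this assay, methyl on this aromatic carbon loses the gain seen with piperidin-1-yl, with a 2.4-fold higher number from compound 2 to compound 3 (0.38 log units; beyond the scatter). Methyl and methoxy cannot be told apart here, with no change at the digits printed from compound 1 to compound 3 (within the scatter), so among these three groups only piperidin-1-yl stands apart. No available evidence accounts for this difference.

On these data alone, it remains open whether the step belongs to piperidin-1-yl specifically or extends to other amines at this place. Dimethylamino, morpholin-4-yl or a longer alkoxy chain such as butoxy would help separate these readings.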